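Dropping the Methyl from Compound 1

This account rests on a few compounds, and the source may have more. Where it says the series, first, only, none or still open, it means among the compounds named here.

Measured in a functional assay on UO-31 cells (Homo sapiens) for inhibition, read by sulforhodamine B assay, with a stated time of 48 h; on this read-out higher numbers stand for weaker inhibition of growth and lower numbers for stronger inhibition of growth:
compound 1 `C=C1CC[C@@H]2[C@](C)(COC(C)=O)[C@H](OC(C)=O)CC[C@@]2(C)[C@H]1CC(Nc1ccc(S(=O)(=O)Nc2nccc(C)n2)cc1)C1=CCOC1=O` gives 10600 nM
compound 2 `C=C1CC[C@@H]2[C@](C)(COC(C)=O)[C@H](OC(C)=O)CC[C@@]2(C)[C@H]1CC(Nc1ccc(S(=O)(=O)Nc2nccs2)cc1)C1=CCOC1=O` gives 16100 nM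

Compound 1 stands at the lower of the two numbers, though the gap to compound 2 is within the scatter. Compound 3 `C=C1CC[C@@H]2[C@](C)(COC(C)=O)[C@H](OC(C)=O)CC[C@@]2(C)[C@H]1CC(Nc1ccc(S(=O)(=O)Nc2ncccn2)cc1)C1=CCOC1=O` differs from compound 1 by a single change, (hydrogen in place of methyl on an aromatic carbon). Within the data shown here, no measured step tests this change directly; the only step available, a 1.5-fold higher number from compound 1 to compound 2 (0.18 log units; within the scatter), swaps the whole ring on the sulfonamide nitrogen and stayed within the scatter. The expected step is therefore none beyond the scatter, a 1.0-fold higher number from compound 1 to compound 3 (0.02 log units; within the scatter). Compound 3 is estimated at 11000 nM, in a range from 5000 nM to 25000 nM.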

Compound 3, concentration for total growth inhibition: 2970 nM
Estimate against measurement, compound 3: 3.7-fold (0.57 log units) above, and the stated range ends above it.
By their numbers in this assay, from the lowest: compound 3; then compounds 1 and 2 (each within the scatter of the next).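

Losing the methyl from the 4-methylpyrimidin-2-yl group gives a 3.6-fold lower number from compound 1 to compound 3 (0.55 log units; beyond the scatter) in this assay, so a single carbon at this position matters more than the earlier ring swap suggested. The pyrimidin-2-yl group also outperforms the 1,3-thiazol-2-yl group, with a 5.4-fold lower number from compound 2 to compound 3 (0.73 log units; beyond the scatter), which leaves compound 3 with the strongest growth inhibition of the three. No evidence here explains why the methyl lowers activity.

Open, going by these compounds, is how other groups at this carbon would behave, such as an amine, a methoxy group or a longer chain like ethyl.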